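This account rests on a few compounds, and the source may have more. Where it says the series, first, only, none or still open, it means among the compounds named here.

Working notes on the series. Compound 1 `COC(=O)c1ccc(-c2cn(CC(=O)Nc3nc(C)cs3)nn2)cc1` is tested in a functional assay on BMDM cells (Mus musculus, strain C57BL/6) for inhibition, with a stated time of 2 days; on this read-out higher numbers stand for weaker inhibition and lower numbers for stronger inhibition. In this assay compound 1 gives > 30000 nM, which is a limit of the assay and not a number. Compound 2 `COC(=O)c1ccc(-c2cn(CC(=O)Nc3cc(C)on3)nn2)cc1` carries 5-methyl-1,2-oxazol-3-yl in place of 4-methyl-1,3-thiazol-2-yl on the amide-type nitrogen. In this assay compound 2 gives > 30000 nM, again a limit of the assay. The step that the two limits leave unreadable from compound 1 to compound 2 is thus unreadable, and the limit of > 30000 nM in this assay, at which 2 of the 2 values shown sit, is all the measured pair shows. Compound 3 `Cc1csc(NC(=O)Cn2cc(-c3ccc([N+](=O)[O-])cc3)nn2)n1` differs from compound 1 by nitro in place of methoxycarbonyl on an aromatic carbon, on an aromatic carbon of a six-membered aromatic ring of carbon only, para to a large group. Among the measured compounds shown here, no measured step touches this position, so nothing seen so far sets a direction or a size. With both measured values at the limit, compound 3 is expected to sit near it as well, the step of a number no higher from compound 1 to compound 3 (the limit leaves the size open) being an estimate only. For compound 3 the estimate in this assay is 30000 nM, with a range from 8000 nM to 100000 nM.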

Compound 3, half-maximal inhibitory concentration: 190 nM
Compound 3: the middle estimate sits 160-fold (2.20 log units) above what was measured; measured number below the stated range.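

Nitro in place of methoxycarbonyl on an aromatic carbon gives an at least 150-fold lower number from compound 1 to compound 3 (2.19 log units; beyond the scatter) in this assay, so this place, para to a large group, can bring the series to a readable number, which the change on the amide-type nitrogen could not show. Compound 1 gives > 30000 nM, a limit of the assay and not a number, so the step has a lower bound and no upper size. The comparison therefore rests on one measured number and one limit: the limit of > 30000 nM in this assay, at which 2 of the 3 values shown sit.

Going by these compounds, it remains open whether the change in this assay is specific to nitro or would also appear with a nitrile, an amine or a carboxylic acid at this place. On these data alone, it is also open whether nitro gives a readable number with 5-methyl-1,2-oxazol-3-yl on the amide-type nitrogen.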